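A few compounds are considered here, and "the series" means these few. Any claim that something is new, unique, unknown or untested is made for them only; others in the source may bear on it.

Compound 1 `CC(C)N(C)c1ccc2cc(NC(=O)CCc3ccc(C(F)(F)F)cc3)ccc2n1` in a functional assay on HEK293 cells for activation of melanin-concentrating hormone receptor 1 (Rattus norvegicus), read by inositol phosphate accumulation (on this read-out lower numbers stand for an effect already at smaller amounts and higher numbers for an effect only at larger amounts of compound), gives 140 nM, the highest of the two numbers recorded so far. Its nearest neighbour is compound 2 `CC(C)C(=O)NC1CCN(c2ccc3cc(NC(=O)CCc4ccc(C(F)(F)F)cc4)ccc3n2)C1`, which in this assay gives 90 nM. Going by the values given here, the one measured step at this position, a 1.6-fold lower number from compound 1 to compound 2 (0.19 log units; within the scatter), exchanged the isopropyl(methyl)amino on an aromatic carbon for a larger ring-bearing group and stayed within the scatter. Compound 3 `O=C(CCc1ccc(C(F)(F)F)cc1)Nc1ccc2nc(N3CCC4(CCNC4)C3)ccc2c1` awaits measurement in this assay; relative to compound 1 it carries a group of 9 heavy atoms (7 carbon, 2 nitrogen; 2 five-membered non-aromatic rings with 1 hetero atom each) in place of a group of 5 heavy atoms (4 carbon, 1 nitrogen; no ring), on an aromatic carbon. Among the compounds with values here, because the only comparable change, a 1.6-fold lower number from compound 1 to compound 2 (0.19 log units; within the scatter), moved the number very little, no step beyond the scatter is expected for compound 3, with a slight lean toward a lower number as the only hint available. The estimated step is a 1.4-fold lower number from compound 1 to compound 3 (0.15 log units; within the scatter). For compound 3 the expected value in this assay is 100 nM, within a range from 35 nM to 300 nM.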

Compound 3, half-maximal effective concentration: 140 nM
Compound 3: the middle estimate sits 1.4-fold (0.15 log units) below what was measured, and the stated range covers the measured number.
By their numbers in this assay, from the lowest: compounds 2, 1 and 3 (each within the scatter of the next).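

In this assay, the aromatic carbon next to the ring nitrogen also accepts a group with 2 five-membered non-aromatic rings and a hydrogen-bond donor, with no change at the digits printed from compound 1 to compound 3 (within the scatter) and a 1.6-fold higher number from compound 2 to compound 3 (0.19 log units; within the scatter). Across compounds 1, 2 and 3, the open-chain isopropyl(methyl)amino and both ring-bearing groups therefore remain within the scatter of one another, so no effect of group size or ring count can be read at this position. No measurement at hand accounts for this flat result.

From the compounds shown here alone, whether any group at this position can give a step beyond the scatter remains open, for example a carboxylic acid or a morpholine. The role of the trifluoromethyl shared by all three compounds is also untested, as a comparison with chlorine in its place would require.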